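The source may hold more compounds than are shown below. What is called first, only, known or untested is meant among the compounds shown, and "the series" means these compounds.

Measured so far in an ADME assay on BJ cells (Homo sapiens) for antiproliferative activity, with a stated time of 72 h; a higher number here means that more compound is needed for the effect, a lower number that less compound is needed:
- Compound 1, `COc1ccc(-c2cc(=O)c3c(OC)cc(OC)cc3n2Cc2ccccc2)cc1`: in this assay compound 1 gives > 34400 nM, which is a limit of the assay.
- Compound 2, `COc1ccc(-c2cc(=O)c3c(OC)cc(OC)cc3n2S(=O)(=O)c2ccc(C=O)cc2)cc1`: in this assay compound 2 gives > 34400 nM, again a limit of the assay.

Compound 2 therefore stands at the edge of what this assay reports, not at a number; the limit of > 34400 nM in this assay, at which 2 of the 2 values shown sit, marks where both values sit. Among the compounds with values here, the only measured step, a step that the two limits leave unreadable from compound 1 to compound 2, gives no readable size.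

Compound 3, `COc1ccc(-c2cc(=O)c3c(OC)cc(OC)cc3n2S(=O)(=O)c2ccc(C)c([N+](=O)[O-])c2)cc1`, differs from compound 2 by 4-methyl-3-nitrophenyl in place of 4-formylphenyl on a sulfonyl sulfur. Within the data shown here, no measured step concerns an exchange of one aryl group on the sulfonyl sulfur for another, and the single step available is unreadable, so no direction can be taken from it. The step that the limit leaves unreadable from compound 2 to compound 3 is expected to be none beyond the scatter, with compound 3 most likely again reported as a limit. Compound 3 is estimated at 50000 nM, with a range from 20000 nM to 150000 nM.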

Compound 3, half-maximal effective concentration: > 51700 nM
Compound 3 ended at the assay's limit; the forecaster's own chance of this, stated with the estimate: 85%; middle value at least 1.0-fold (0.01 log units) from the limit.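

Within the data shown here, compound 2 and compound 3 both end at limits in this assay, so no step between them can be read. Compound 3 gives > 51700 nM, which is a limit of the assay. The compounds shown leave open whether any group on the sulfonyl sulfur gives a readable value in this assay.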